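Adding a Methoxy Group to Compound 3

A few compounds are considered here, and "the series" means these few. Any claim that something is new, unique, unknown or untested is made for them only; others in the source may bear on it.

Of the compounds shown here, three sharing one core have been measured in a functional assay on Malme-3M cells (Homo sapiens) for antiproliferative activity, with a stated time of 48 h; on this read-out higher numbers stand for weaker inhibition of growth and lower numbers for stronger inhibition of growth. Compound 1 `Cc1cc(O)c(C2=NN(c3ccc(S(N)(=O)=O)cc3)C(c3ccccc3O)C2)cc1Cl` gives 2720 nM. Compound 2 `Cc1cc(O)c(C2=NN(c3ccc(S(N)(=O)=O)cc3)C(/C=C/c3ccccc3)C2)cc1Cl` gives 3010 nM, and compound 3 `COc1ccc(C2CC(c3cc(Cl)c(C)cc3O)=NN2c2ccc(S(N)(=O)=O)cc2)cc1OC` gives 3650 nM. The step of a 1.1-fold higher number from compound 1 to compound 2 (0.04 log units; within the scatter) exchanges the group on the saturated ring carbon, as do the step of a 1.3-fold higher number from compound 1 to compound 3 (0.13 log units; within the scatter) and the step of a 1.2-fold higher number from compound 2 to compound 3 (0.08 log units; within the scatter); none of them reaches beyond the scatter. Compound 3 thus stands with the highest of the three numbers, yet it is separated from the other two by nothing that repeated measurement could resolve.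

Compound 4 `COc1ccc(C2CC(c3cc(Cl)c(C)cc3O)=NN2c2ccc(S(N)(=O)=O)cc2)c(OC)c1OC` differs from compound 3 in one place: methoxy in place of hydrogen on an aromatic carbon, so that 3,4-dimethoxyphenyl becomes 2,3,4-trimethoxyphenyl. For the measured compounds named here, no measured step adds or removes a single group on this aryl ring; the three measured steps only swap the whole aryl group, and each stayed within the scatter. Since exchanging the whole group left the read-out unmoved, the entering methoxy is expected to give a step no larger than the scatter, a 1.0-fold higher number from compound 3 to compound 4 (0.02 log units; within the scatter), with no preferred direction. Compound 4 is therefore estimated at 3800 nM in this assay, with a range from 1500 nM to 9500 nM.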

Compound 4, concentration for 50% growth inhibition: 2080 nM
Beside the measured number, compound 4's estimate is 1.8-fold (0.26 log units) above it, and the stated range covers the measured number.
By their numbers in this assay, from the lowest: compounds 4, 1, 2 and 3 (each within the scatter of the next).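

In this assay, for the compounds shown here, the methoxy that enters here, ortho to a large group and ortho to a methoxy group, is the first change inside the aryl ring rather than an exchange of the whole group, and it gives a 1.8-fold lower number from compound 3 to compound 4 (0.24 log units; within the scatter) while staying within the scatter, so this crowded position on the ring accepts the extra methoxy without a resolvable shift in the read-out. Read against the other groups on the saturated ring carbon, 2,3,4-trimethoxyphenyl gives a 1.4-fold lower number from compound 2 to compound 4 (0.16 log units; within the scatter) and a 1.3-fold lower number from compound 1 to compound 4 (0.12 log units; within the scatter) with both steps also within the scatter, so the four groups now seen at that carbon, including this more heavily substituted aryl, cannot be told apart on these numbers. Nothing available on these compounds bears on this result.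

The compounds shown leave open whether this position responds at all, since only methoxy and hydrogen are compared on this ring carbon. An amine, a carboxylic acid or a longer chain such as butoxy in the same place would show whether the read-out can move beyond the scatter here, or whether it stays as flat as it has so far.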